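The compounds below may be only part of what the source reports. "The series", "measured", "known", "first", "only" and "open" are said of these compounds alone.

Measured so far:
Compound 1 `C=C(CC)C(=O)c1ccc(OCC(=O)OCCOCCOCCOCCO)c(Cl)c1Cl`; compound 2 `C=C(CC)C(=O)c1ccc(OCC(=O)OCCOCCO)c(Cl)c1Cl`.

In an ADME assay on a cell-free system (serum, Homo sapiens) for pharmacokinetics (on this read-out higher numbers stand for a longer-lived compound and lower numbers for a shorter-lived compound), compound 1 gives < 0.0334 h, which is a limit of the assay. In this assay compound 2 likewise gives < 0.0334 h, again a limit. The step that the two limits leave unreadable from compound 1 to compound 2 therefore cannot be read, and the limit of < 0.0334 h in this assay, at which 2 of the 2 values shown sit, shows both known values sitting at the same limit. Compound 3 `C=C(CC)C(=O)c1ccc(OCC(=O)OCCOCCOCCOCCOCCOCCO)c(Cl)c1Cl` differs from compound 2 by a group of 12 heavy atoms (8 carbon, 4 oxygen; no ring) in place of a hydrogen atom, on an oxygen on a saturated carbon. Among the compounds with values here, the one measured step bears on this kind of chain extension but gives no readable size, so compound 3 is expected to show no step beyond the scatter, the estimated step being a step that the limit leaves unreadable from compound 2 to compound 3. Compound 3 is thus estimated at 0.02 h, within a range of 0.005 h to 0.05 h, most likely reported once more only as a limit.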

Compound 3, half-life: < 0.0334 h
Compound 3 was reported as a limit; the forecaster's own chance of this, stated with the estimate: 85%; the middle value lies beyond the limit too.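

In this assay compound 3 gives < 0.0334 h as a limit. Within the data shown here, no step among compound 1, compound 2 and compound 3 can be read: the limit of < 0.0334 h in this assay, at which 3 of the 3 values shown sit. The compounds shown leave open whether chain length changes the half-life at all.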